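The compounds below may be only part of what the source reports. "The series", "measured", "known", "first", "only" and "open" are said of these compounds alone.

Three compounds have values so far in a physicochemical assay for lipophilicity, read by HPLC, at pH 7.4; on this read-out lower numbers stand for lower lipophilicity and higher numbers for higher lipophilicity
compound 1 `Cc1ccc([C@@H](C)Oc2cc3onc(CCC(=O)O)c3cc2Cl)nc1` gives 2.42
compound 2 `C[C@@H](Oc1cc2oc(=O)n(CCC(=O)O)c2cc1Cl)c1ccc(F)cn1` gives 1.98
compound 3 `CC(C)Cc1cc2oc(=O)n(CCC(=O)O)c2cc1Cl` gives 3.03

Compound 2 stands lowest of the three. Both of the others lie beyond the scatter from it, with compound 1 nearest and compound 3 furthest.

The next compound, compound 4 `C[C@@H](Oc1cc2oc(=O)n(CCC(=O)O)c2cc1Cl)c1cccnn1`, has not yet been measured. It differs from compound 2 in one place pyridazin-3-yl in place of 5-fluoropyridin-2-yl on a saturated chain carbon bound to an oxygen on an aromatic ring and a saturated chain carbon with pyridazin-3-yl in place of 5-fluoropyridin-2-yl on a saturated chain carbon bound to an oxygen on an aromatic ring and a saturated chain carbon. The entering ring has two hetero atoms and two hydrogen-bond acceptors, and the fluorine leaves with the old one.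

Among the measured compounds shown here, no two measured compounds differ in only one place, so the data offer no direct guide to this change, and the expectation remains a judgement. The estimated step of a number 0.88 log units lower from compound 2 to compound 4 (beyond the scatter) is expected to be a fall beyond the scatter. Compound 4 is expected at 1.1 in a range from 0.6 to 1.6 when it is measured.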

Compound 4, distribution coefficient: 0.83
Compound 4: middle estimate off by 0.27 log units, on the high side; the range from low to high includes it.
By their numbers in this assay, from the lowest: compound 4; then compound 2; then compound 1; then compound 3.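

In this assay, pyridazin-3-yl in place of 5-fluoropyridin-2-yl on a saturated chain carbon bound to an oxygen on an aromatic ring and a saturated chain carbon gives a large fall (a number 1.15 log units lower from compound 2 to compound 4 (beyond the scatter)), beyond the scatter. Among the compounds shown here, this is the first pair here that differs in one place, and it shows that the number responds strongly to the ring at this position while the rest of the molecule stays the same. No measurement shown accounts for the size of this fall.

The compounds shown leave open whether the fall goes with the second ring nitrogen or with the departure of the fluorine, and an unsubstituted pyridin-2-yl at this place would separate the two. As far as these compounds go, it also remains open whether a pyrimidin-2-yl ring would give a similar step, or whether the same change would do so on the core of compound 1.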